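A Smaller Group on the Sulfonyl Sulfur

The compounds below may be only part of what the source reports. "The series", "measured", "known", "first", "only" and "open" are said of these compounds alone.

Among the measured compounds shown here, in an ADME assay on a cell-free system (plasma, Homo sapiens) (on this read-out lower numbers stand for a smaller free fraction and higher numbers for a larger free fraction), compound 1 `Cc1ccc(S(=O)(=O)N(C)C(C)C)cc1C#Cc1cc(Cl)ccc1OCC(=O)O` gives 0.002 as the only number in this small series. Compound 2 `COCCNS(=O)(=O)c1ccc(C)c(C#Cc2cc(Cl)ccc2OCC(=O)O)c1` carries the entry "not determined" (no result reported) instead of a number. Compound 3 `Cc1ccc(S(=O)(=O)N2CCCCC2C)cc1C#Cc1cc(Cl)ccc1OCC(=O)O` also stands at "not determined" (no result reported) and so offers no value to start from. Compound 4 `Cc1ccc(S(=O)(=O)N(C)C)cc1C#Cc1cc(Cl)ccc1OCC(=O)O` keeps the shared core and changes one group, as dimethylamino in place of 2-methylpiperidin-1-yl on a sulfonyl sulfur shows, with dimethylamino in place of 2-methylpiperidin-1-yl on a sulfonyl sulfur. For the measured compounds named here, no measured step shows what such a swap does, so the only guide is compound 1 at 0.002 in this series. A small rise in this assay is expected, close to the usual scatter. For compound 4 the estimated value is 0.004 with an expected range from 0.0015 to 0.01 around it.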

Compound 4, unbound fraction: 0.004
Compound 4: the middle estimate sits on the measured number at the digits printed, and the stated range covers the measured number.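

In this assay, among the compounds shown here, the only step that can be read at this position is a 2.0-fold higher number from compound 1 to compound 4 (0.30 log units; within the scatter), for methyl in place of isopropyl on a sulfonamide nitrogen. Trimming this group therefore gives no shift that can be told apart from repeat-measurement noise, and no step involving compound 3 can be read. Nothing available points to a cause for this result. Still open, from the compounds shown here alone, is whether morpholin-4-yl on the sulfonyl sulfur, or a chain ending in an amine, would give a step beyond the scatter.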